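The source may hold more compounds than are shown below. What is called first, only, known or untested is meant among the compounds shown, and "the series" means these compounds.

Measured so far in a functional assay on PC-3 cells (Homo sapiens) for cytotoxicity, read by MTT assay, with a stated time of 48 h; a lower number here means a stronger inhibitor, a higher number a weaker inhibitor:
compound 1 `COc1cc(-c2nnc3n2NC(c2cccs2)C(C(=O)c2ccc(F)cc2)S3)cc(OC)c1OC` — 27400 nM
compound 2 `COc1cc(-c2nnc3n2NC(c2ccco2)C(C(=O)c2cccc(Br)c2)S3)cc(OC)c1OC` — 63900 nM
compound 3 `COc1cc(-c2nnc3n2NC(c2cccs2)C(C(=O)c2ccc(Cl)cc2)S3)cc(OC)c1OC` — 32500 nM

Compound 2 carries the highest of the three numbers; its gap to compound 3 lies within the scatter, while its gap to compound 1 lies beyond it. Going by the values given here, the only step between compounds that differ in a single place is a 1.2-fold higher number from compound 1 to compound 3 (0.07 log units; within the scatter), a halogen exchange on the phenyl that bears the carbonyl, and it stays within the scatter.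

Compound 4 `COc1cccc(C(=O)C2Sc3nnc(-c4cc(OC)c(OC)c(OC)c4)n3NC2c2ccco2)c1` is to be measured in this assay. It differs from compound 2 in one place: methoxy in place of bromo on an aromatic carbon. Among the compounds with values here, no measured pair shows a methoxy entering in place of a halogen on this phenyl, so the only step that bears on the change is the halogen swap from compound 1 to compound 3, which moved the number very little. On that basis no step beyond the scatter is expected, with a slight lean toward a lower number because compound 2 already sits at 63900 nM, the top of the set. The estimate for compound 4 is 50000 nM, with a range from 20000 nM to 130000 nM, which means an expected step of a 1.3-fold lower number from compound 2 to compound 4 (0.11 log units; within the scatter).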

Compound 4, half-maximal inhibitory concentration: 84600 nM
Compound 4: the middle estimate sits 1.7-fold (0.23 log units) below what was measured; low and high end bracket the measured number.
By their numbers in this assay, from the lowest: compounds 1, 3, 2 and 4 (each within the scatter of the next, the first and the last beyond it).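

In this assay, going by these compounds alone, the step from 3-bromophenyl to 3-methoxyphenyl gives a 1.3-fold higher number from compound 2 to compound 4 (0.12 log units; within the scatter), the first single-place reading at this position and the first in which a non-halogen group replaces a halogen on this phenyl. Although the exchange removes a bromine and introduces two heavy atoms and a hydrogen-bond acceptor, compound 2 and compound 4 cannot be told apart in this assay. Together with the halogen exchange a 1.2-fold higher number from compound 1 to compound 3 (0.07 log units; within the scatter), this means that both single-place steps shown on this phenyl stay within the scatter, with no compound here going against that, though two steps at differing places make a thin basis for any pattern, and no available measurement bears on why this change leaves the reading so little moved.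

From the compounds shown here alone, it remains open whether an amine or a carboxylic acid at this meta position would give a step beyond the scatter, or whether such a group would also leave the reading unresolved. Within the data shown here, also open is whether 3-bromophenyl and 3-methoxyphenyl would read alike when paired with the ring that compound 1 and compound 3 carry in place of the one in compound 2.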